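The source may hold more compounds than are shown below. What is called first, only, known or untested is meant among the compounds shown, and "the series" means these compounds.

Compound 3 `Clc1[nH]ccc2ncnc1-2` gives 6% in a functional assay (Homo sapiens) for inhibition of Nucleic Acid, tested at 100 uM (on this read-out lower numbers stand for less inhibition and higher numbers for more inhibition at the one concentration tested (going by the name of the read-out)), the second highest of the three numbers. Compound 1 `CSc1[nH]ccc2ncnc1-2` gives 4%; the step of a number 2 percentage points higher from compound 1 to compound 3 (within the scatter), chloro in place of methylsulfanyl on an aromatic carbon, lies within the scatter. Compound 2 `CCCCCCNc1[nH]ccc2ncnc1-2` gives 53%, beyond the scatter from compound 3. Compound 4 `CCNc1[nH]ccc2ncnc1-2` differs from compound 3 by ethylamino in place of chloro on an aromatic carbon. For the measured compounds named here, no measured step exchanges chloro for an amino group; the single measured step is within the scatter and does not bear on this change. The numbers of compound 2 and compound 3 show hexylamino well above chloro, so ethylamino is expected to fall between them. Compound 4 is expected to give 25%, between 5% and 50%, an expected upward step of a number 19 percentage points higher from compound 3 to compound 4 (beyond the scatter) beyond the scatter.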

Compound 4, a percentage reported as inhibition, at one concentration (the size of the read-out at that concentration, not a potency): 3%
Beside the measured number, compound 4's estimate is 22 percentage points above it; the measured number lies below the stated range.
By their numbers in this assay, from the lowest: compounds 4, 1 and 3 (each within the scatter of the next); then compound 2.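

The steps of a number 3 percentage points lower from compound 3 to compound 4 (within the scatter) and a number 1 percentage points lower from compound 1 to compound 4 (within the scatter) place ethylamino level with chloro and methylsulfanyl in this assay and show that a nitrogen link at this position does not on its own raise the number. The difference lies in the chain on that nitrogen: a number 50 percentage points lower from compound 2 to compound 4 (beyond the scatter) separates ethylamino from hexylamino on the shared core. Nothing available explains this chain-length dependence. Still open, on these data alone, is the chain length at which the number starts to rise, which butylamino would help to place, and whether a longer chain such as octylamino goes higher still.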